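Removing one aryl methoxy from the fluoro analogue

A few compounds are considered here, and "the series" means these few. Any claim that something is new, unique, unknown or untested is made for them only; others in the source may bear on it.

Measured compounds in a functional assay on NCI-H460 cells (Homo sapiens) for antiproliferative activity, with a stated time of 72 h; a lower number here means a stronger inhibitor, a higher number a weaker inhibitor:
compound 1 `C=CC[C@H]1C[C@]2([C@@H](C)Cc3ccc(OC)c(OC)c3)OCOC2=CC1=O` gives 260 nM.
compound 2 `C=CC[C@H]1C[C@]2([C@@H](C)Cc3ccc(O)cc3)OCOC2=CC1=O` gives > 20000 nM, which is a limit of the assay.
compound 3 `C=CC[C@H]1C[C@]2([C@@H](C)Cc3cc(OC)c(OC)cc3F)OCOC2=CC1=O` gives 120 nM.

Compound 3 stands lowest among the numbers shown; the nearest is compound 1, and the step is a 2.2-fold lower number from compound 1 to compound 3 (0.34 log units; beyond the scatter). Compound 2 reaches only a limit of the assay and is not a number. Compound 4 `C=CC[C@H]1C[C@]2([C@@H](C)Cc3ccc(OC)cc3F)OCOC2=CC1=O` differs from compound 3 by hydrogen in place of methoxy on an aromatic carbon. Within the data shown here, no measured step removes a methoxy group on its own; compound 2, with a single hydroxy group and no fluoro, differs from compound 3 in more than one place, so its values and those of compound 3 can only be set side by side. For compound 4 in this assay a weaker result is expected, estimated at 1000 nM (range 200 nM to 8000 nM), a step of an 8.3-fold higher number from compound 3 to compound 4 (0.92 log units; beyond the scatter).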

Compound 4, half-maximal inhibitory concentration: 94 nM
Compound 4: middle estimate off by 11-fold (1.03 log units), on the high side; measured number outside the range, below it.
By their numbers in this assay, from the lowest: compounds 4 and 3 (each within the scatter of the next); then compound 1. At a limit, above all of these: compound 2.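

In this assay, hydrogen in place of the methoxy para to the fluoro group leaves the result within the scatter: a 1.3-fold lower number from compound 3 to compound 4 (0.11 log units; within the scatter). Among these compounds, this is the first single-place step at a methoxy group, and with the fluoro group present, this methoxy is not required to keep the value of the series. Nothing measured here bears on a cause for this result.

Going by these compounds, whether an amine or a carboxylic acid at this position would be accepted remains open. So does the effect of the same methoxy removal without the fluoro group.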